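Adding fluoro to the phenyl group of compound 3

The compounds below may be only part of what the source reports. "The series", "measured", "known", "first", "only" and "open" are said of these compounds alone.

In a functional assay on A549 cells (Homo sapiens) for inhibition, read by MTT assay, with a stated time of 48 h (a lower number here means a stronger inhibitor of growth, a higher number a weaker inhibitor of growth), compound 3 `Cn1cc(C2CC(c3ccccc3)=NN2C(=O)c2cccnc2)c2cc(Br)ccc21` gives 1600 nM, the higher of the two exact numbers. Compound 2 `COc1cc(C2=NN(C(=O)c3ccc(C)nc3)C(c3cn(C)c4ccccc34)C2)cc(OC)c1OC` gives 230 nM. For compound 1 `Cn1cc(C2CC(c3ccccc3)=NN2C(=O)c2cccnc2)c2ccccc21`, only a limit was obtained, > 10000 nM.

Compound 4 `Cn1cc(C2CC(c3ccc(F)cc3)=NN2C(=O)c2cccnc2)c2cc(Br)ccc21` carries one change, fluoro in place of hydrogen on an aromatic carbon, turning phenyl into 4-fluorophenyl. Among the compounds with values here, the only measured single-change step involves a different group, bromo in place of hydrogen, and it gave an at least 6.2-fold lower number from compound 1 to compound 3 (0.79 log units; beyond the scatter). Within the data shown here, no such step tests the phenyl group, so no change beyond the scatter is expected in this assay. The expected change is a 1.2-fold lower number from compound 3 to compound 4 (0.09 log units; within the scatter). Compound 4 is estimated at 1300 nM, within an expected range of 450 nM to 3800 nM.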

Compound 4, concentration for 50% growth inhibition: 1380 nM
Compound 4: the middle estimate sits 1.1-fold (0.03 log units) below what was measured; low and high end bracket the measured number.
By their numbers in this assay, from the lowest: compound 2; then compounds 4 and 3 (each within the scatter of the next). At a limit, above all of these: compound 1.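

In this assay, within the data shown here, this is the first step that tests the phenyl group, and it is small: a 1.2-fold lower number from compound 3 to compound 4 (0.06 log units; within the scatter). Fluoro on this aromatic carbon, para to a large group, therefore leaves growth inhibition within the scatter of compound 3, so this position accepts this one small change without a measurable effect. Nothing measured here gives a reason for this result.

As far as these compounds go, whether the same position would accept an amine or a carboxylic acid remains open. Compound 2 differs from compound 4 in more than one place, so what separates their values cannot be assigned to any single change.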